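Hydroxy to isobutoxy on compound 3

The compounds below may be only part of what the source reports. "The series", "measured", "known", "first", "only" and "open" are said of these compounds alone.

Of the compounds shown here, three have values so far in an ADME assay on microsomes from liver (Rattus norvegicus) for metabolic stability; a lower number here means that the compound disappears faster, a higher number that the compound lasts longer. Compound 1 `O=c1c(-c2ccc(F)cc2)c[nH]c2ccnc(Nc3ccc(Oc4ccnc5cc(OCCO)ccc45)c(F)c3)c12` gives 1.51 h, compound 2 `COCCOc1cc2nccc(Oc3ccc(Nc4nccc5[nH]cc(-c6ccc(F)cc6)c(=O)c45)cc3F)c2cc1OC` gives 1.06 h, and compound 3 `O=c1c(-c2ccc(F)cc2)c[nH]c2ccnc(Nc3ccc(Oc4ccnc5cc(O)ccc45)c(F)c3)c12` gives 0.893 h. Compound 3 stands within the scatter of both of the others.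

Compound 4 `CC(C)COc1ccc2c(Oc3ccc(Nc4nccc5[nH]cc(-c6ccc(F)cc6)c(=O)c45)cc3F)ccnc2c1` follows from compound 3 by one change, hydroxy to isobutoxy (isobutyl in place of hydrogen on an oxygen on an aromatic ring), with isobutyl in place of hydrogen on an oxygen on an aromatic ring. Within the data shown here, one measured step bears on this oxygen: a 1.7-fold lower number from compound 1 to compound 3 (0.23 log units; within the scatter), with hydrogen in place of 2-hydroxyethyl. That step stays within the scatter. Among the measured compounds shown here, no measured compound carries isobutyl on this oxygen, so the step is only a loose guide. The expected step is a 1.2-fold higher number from compound 3 to compound 4 (0.09 log units; within the scatter), and no step beyond the scatter is expected in this assay. The estimate for compound 4 is 1.1 h, with an expected range of 0.55 h to 2.1 h.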

Compound 4, half-life: 1.5 h
Compound 4: middle estimate off by 1.4-fold (0.13 log units), on the low side; measured number inside the range.
By their numbers in this assay, from the lowest: compounds 3, 2, 4 and 1 (each within the scatter of the next).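

In this assay the oxygen on the aromatic ring now carries a branched, hydroxyl-free group, and isobutyl in place of hydrogen gives a 1.7-fold higher number from compound 3 to compound 4 (0.23 log units; within the scatter), so this group joins 2-hydroxyethyl in leaving the number inside the scatter of the free hydroxy compound. Between the two chains, a 1.0-fold lower number from compound 1 to compound 4 (0.00 log units; within the scatter) shows that isopropyl in place of hydroxymethyl at the chain end leaves no readable difference, so the terminal hydroxyl of compound 1 is not required for a number of this size. Nothing on hand explains why these values sit so close together.

Going by these compounds, whether any group on this oxygen can move the half-life beyond the scatter stays open. An amine or a carboxylic acid at the chain end, or a longer chain, would test this.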